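This account rests on a few compounds, and the source may have more. Where it says the series, first, only, none or still open, it means among the compounds named here.

The measured compounds in a physicochemical assay for lipophilicity, read by HPLC, measured as octanol-water partition; a higher number here means a more lipophilic compound, a lower number a more polar compound:

Compound 1 `CN1CCN(C[C@H]2CN(c3ccc(-n4cc(-c5ccccn5)cn4)c(F)c3)C(=O)O2)CC1` gives 2.2.
Compound 2 `COC(=O)CC1CCN(C[C@H]2CN(c3ccc(-n4cc(-c5ccccn5)cn4)c(F)c3)C(=O)O2)CC1` gives 1.78.
Compound 3 `CS(=O)(=O)NC[C@H]1CN(c2ccc(-n3cc(-c4ccccn4)cn3)c(F)c2)C(=O)O1` gives 1.38.

Compound 1 stands highest of the three in this assay. The nearest number belongs to compound 2, and the step there is a number 0.42 log units lower from compound 1 to compound 2 (beyond the scatter). The furthest belongs to compound 3, with a number 0.82 log units lower from compound 1 to compound 3 (beyond the scatter). Between the two lower compounds the step is a number 0.40 log units lower from compound 2 to compound 3 (beyond the scatter).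

Compound 4 `O=C(NC[C@H]1CN(c2ccc(-n3cc(-c4ccccn4)cn3)c(F)c2)C(=O)O1)C(F)F` has not yet been measured. It differs from compound 1 in one place: ((difluoromethyl)carbonyl)amino in place of 4-methylpiperazin-1-yl on a saturated chain carbon bound to a saturated ring carbon. The step that bears most directly on this is the one that also removes 4-methylpiperazin-1-yl from that same position and puts in a short chain with one hydrogen-bond donor, namely a number 0.82 log units lower from compound 1 to compound 3 (beyond the scatter), a modest downward move; the other two steps show that every departure from 4-methylpiperazin-1-yl seen so far has gone downward. A modest downward step in this assay is therefore expected, estimated as a number 0.60 log units lower from compound 1 to compound 4 (beyond the scatter). Compound 4 is expected to come out near 1.6, within a range from 1.2 to 2.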

Compound 4, partition coefficient: 1.9
Estimate against measurement, compound 4: 0.30 log units below, and the stated range covers the measured number.
By their numbers in this assay, from the lowest: compound 3; then compounds 2, 4 and 1 (each within the scatter of the next, the first and the last beyond it).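

In this assay, the place on a saturated chain carbon bound to a saturated ring carbon can lose 4-methylpiperazin-1-yl without a step beyond the scatter: ((difluoromethyl)carbonyl)amino gives a number 0.30 log units lower from compound 1 to compound 4 (within the scatter), so not every departure from that ring moves the number clearly downward. On the amine nitrogen, the group attached also counts, as (difluoromethyl)carbonyl in place of methylsulfonyl gives a number 0.52 log units higher from compound 3 to compound 4 (beyond the scatter). Against 4-((methoxycarbonyl)methyl)piperidin-1-yl, the new group gives a number 0.12 log units higher from compound 2 to compound 4 (within the scatter), so two replacements with no ring in common with each other's side chain are not separated here.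

Nothing in the data shown explains why these steps differ in size. As far as these compounds go, whether a plain acetyl group on that nitrogen, with no fluorine, would read like (difluoromethyl)carbonyl or like methylsulfonyl remains open.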